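Dimethylcarbamoyl in Place of Methylsulfonyl on the Amine

The source may report more compounds than this note shows. Statements on the series, on what has been measured and on what is new or still open speak of the compounds shown alone.

Measured compounds:
compound 1 `COC(=O)N[C@H]1Cc2ccc(NC(=O)c3cc(C)ccc3-c3ccc(C(F)(F)F)cc3)cc2C1`: 170 nM
compound 2 `CS(=O)(=O)NC1Cc2ccc(NC(=O)c3ccccc3-c3ccc(C(F)(F)F)cc3)cc2C1`: 120 nM

In an assay on isolated protein for inhibition of microsomal triglyceride transfer protein large subunit (Homo sapiens) (on this read-out lower numbers stand for stronger inhibition and higher numbers for weaker inhibition), compound 2 gives 120 nM. Compound 1 gives 170 nM, and the two values lie within the scatter of each other, so neither can be called the stronger inhibitor. Compound 3 `CN(C)C(=O)NC1Cc2ccc(NC(=O)c3ccccc3-c3ccc(C(F)(F)F)cc3)cc2C1` has not yet been measured. It differs from compound 2 in one place: dimethylcarbamoyl in place of methylsulfonyl on an amine nitrogen. Among the measured compounds shown here, no measured pair shows this exchange, so the size of its effect is unknown. The expectation is a step of no more than the scatter, in either direction. Compound 3 is estimated at 150 nM, with a range from 50 nM to 450 nM. That estimate means a step of a 1.3-fold higher number from compound 2 to compound 3 (0.10 log units; within the scatter), expected to stay within the scatter.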

Compound 3, half-maximal inhibitory concentration: 80 nM
For compound 3 the middle estimate is 1.9-fold (0.27 log units) above the measured one, and the stated range covers the measured number.
By their numbers in this assay, from the lowest: compounds 3, 2 and 1 (each within the scatter of the next, the first and the last beyond it).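

In this assay, putting dimethylcarbamoyl in place of methylsulfonyl on the amine nitrogen gives a 1.5-fold lower number from compound 2 to compound 3 (0.18 log units; within the scatter) and so stays within the scatter. This first direct comparison at this position shows that the nitrogen can carry either group with no difference that can be told from the scatter. No measurement available here accounts for this result. From the compounds shown here alone, whether an acetyl group, a longer chain or a carboxylic acid on this nitrogen would move the number beyond the scatter remains open. Also open, going by these compounds, is whether the exchange behaves alike on other cores.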